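The compounds below may be only part of what the source reports. "The series", "measured", "known", "first", "only" and "open" are said of these compounds alone.

Measured compounds:
- compound 1, `Cc1cccc(Nc2nc(-c3ccncc3-c3ccc(C(C)C)cc3)cs2)c1`: in a functional assay on RCC4 cells (Homo sapiens) for inhibition, read by XTT assay, with a stated time of 4 days (a lower number here means a stronger inhibitor, a higher number a weaker inhibitor), compound 1 gives > 40000 nM; 40700 nM (2 entries).
- compound 2, `COC(=O)C=CC(=O)c1sc(Nc2cccc(C)c2)nc1-c1ccncc1`: in this assay compound 2 gives 2510 nM.
- compound 3, `Cc1cccc(Nc2nc(-c3ccnc(-c4cn(Cc5ccccc5)nn4)c3)cs2)c1`: in this assay compound 3 gives 2100 nM; 2140 nM (2 entries).

Going by the values given here, compound 2 stands on the only number reported for it in this assay; two further entries carry no single number. Its value and that of compound 3 lie within the usual scatter of each other, so no order is claimed between them. The repeated entries of compound 3 the several entries of compound 3 in this assay, 2100 nM; 2140 nM (2 entries) and of compound 1 the several entries of compound 1 in this assay, > 40000 nM; 40700 nM (2 entries) show how tightly repeats agree here.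

Compound 4, `Cc1cccc(Nc2nc(-c3ccncc3)c(C(=O)N(C)C)s2)c1`, is not yet measured. It differs from compound 2 by dimethylamino in place of 2-(methoxycarbonyl)ethenyl on a carbonyl carbon. Among the compounds with values here, no step between measured compounds covers this change, so its size is open; a moderate move toward a weaker inhibitor in this assay is expected, beyond the scatter but not large. Compound 4 is expected to give 8000 nM (range 2000 nM to 40000 nM), a step of a 3.2-fold higher number from compound 2 to compound 4 (0.50 log units; beyond the scatter) that is expected rather than known.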

Compound 4, half-maximal inhibitory concentration: 16200 nM
Compound 4: middle estimate off by 2.0-fold (0.31 log units), on the low side; the range from low to high includes it.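

In this assay, going by these compounds alone, the group on this carbonyl carbon matters: dimethylamino in place of 2-(methoxycarbonyl)ethenyl gives a 6.5-fold higher number from compound 2 to compound 4 (0.81 log units; beyond the scatter), the only step so far and one beyond the scatter. The position therefore gives up part of the inhibition when the group is replaced, yet compound 4 still returns a measured number rather than a limit.

Going by these compounds, whether the loss tracks the ester, the double bonds or the shorter group stays open, as does how a carboxylic acid, a morpholine amide or a longer chain on this carbonyl carbon would read. No measurement shown gives a cause for the step.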